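Compound 4: methoxy in place of the amino group

A few compounds are considered here, and "the series" means these few. Any claim that something is new, unique, unknown or untested is made for them only; others in the source may bear on it.

Compound 1 `COc1cc(Oc2ccccc2NC(C)=C2C(=O)CC(c3ccccc3)CC2=O)ccc1N`: 12 nM
Compound 2 `CC(Nc1ccccc1Oc1cccc(N)c1)=C1C(=O)CC(c2ccccc2)CC1=O`: 42 nM
Compound 3 `CC(Nc1ccccc1Oc1ccc(N)cc1)=C1C(=O)CC(c2ccccc2)CC1=O`: 37 nM

These values come from a functional assay on CCRF-CEM cells (Homo sapiens) for antiproliferative activity, read by cell counting, with a stated time of 96 h; on this read-out lower numbers stand for stronger inhibition and higher numbers for weaker inhibition. Compound 3 stands level with compound 2 within the scatter, and compound 1 gives the lowest number, with a modest gap: a 3.1-fold higher number from compound 1 to compound 3 (0.49 log units; beyond the scatter). Compound 4 `COc1cccc(Oc2ccccc2NC(C)=C2C(=O)CC(c3ccccc3)CC2=O)c1` differs from compound 3 in one place: 3-methoxyphenyl in place of 4-aminophenyl on an oxygen on an aromatic ring. It carries 3-methoxyphenyl in place of 4-aminophenyl on an oxygen on an aromatic ring.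

Among the compounds with values here, two measured steps bear on this change. Exchanging 3-aminophenyl for 4-aminophenyl gave a 1.1-fold lower number from compound 2 to compound 3 (0.06 log units; within the scatter), so that exchange left the number within the scatter. Compound 1 shows a methoxy group alongside the amino group, and its step to compound 2 is a 3.5-fold higher number from compound 1 to compound 2 (0.54 log units; beyond the scatter). Within the data shown here, no measured compound lacks the amino group, so the effect of losing it is unknown. A modest move towards a higher number is expected, with considerable uncertainty. The estimated step is a 2.2-fold higher number from compound 3 to compound 4 (0.33 log units; beyond the scatter). For compound 4 the expected value is 80 nM, with an estimated range from 20 nM to 300 nM.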

Compound 4, half-maximal inhibitory concentration: 41 nM
Estimate against measurement, compound 4: 2.0-fold (0.29 log units) above; low and high end bracket the measured number.
By their numbers in this assay, from the lowest: compound 1; then compounds 3, 4 and 2 (each within the scatter of the next).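

Within this assay, 3-methoxyphenyl in place of 4-aminophenyl gives a 1.1-fold higher number from compound 3 to compound 4 (0.04 log units; within the scatter), and methoxy in place of amino gives a 1.0-fold lower number from compound 2 to compound 4 (0.01 log units; within the scatter), so among these three compounds an amino group is not required to hold the number at this level. Hydrogen in place of amino on the ring that also carries the methoxy group, however, gives a 3.4-fold higher number from compound 1 to compound 4 (0.53 log units; beyond the scatter), so the amino group counts only where it stands together with methoxy. No accompanying data offer an explanation for this contrast.

From the compounds shown here alone, it remains open whether the low number of compound 1 depends on the amino group specifically or would also be reached with a hydroxyl or a dimethylamino group in its place. How a plain phenyl group would compare on the same oxygen is also unresolved.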